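The source may report more compounds than this note shows. Statements on the series, on what has been measured and on what is new or still open speak of the compounds shown alone.

Measured compounds:
compound 1 `CC(C(=O)NCc1ccc(C(F)(F)F)nc1NCc1cccnc1)c1ccc(NS(C)(=O)=O)c(F)c1`, "not active" (no number reported) in a functional assay on CHO-K1 cells for antagonist activity at transient receptor potential cation channel subfamily V member 1 (Homo sapiens), read by FLIPR; a higher number here means a weaker inhibitor, a lower number a stronger inhibitor;
compound 2 `Cc1ccc(CC2CCN(c3nc(C(F)(F)F)ccc3CNC(=O)C(C)c3ccc(NS(C)(=O)=O)c(F)c3)CC2)cc1`, 0.2 nM;
compound 3 `CC(C(=O)NCc1ccc(C(F)(F)F)nc1N1CCC2(CC1)CC(C(C)(C)C)=NO2)c1ccc(NS(C)(=O)=O)c(F)c1`, 3.8 nM.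

Compound 1 stands apart from the other two: in this assay compound 1 is reported only as "not active" (no number reported), without a number, whereas compound 2 and compound 3 each give a measured inhibition constant. Compound 4 `CC(C(=O)NCc1ccc(C(F)(F)F)nc1N1CCN(C)CC1)c1ccc(NS(C)(=O)=O)c(F)c1` has not yet been tested. It differs from compound 1 in one place: 4-methylpiperazin-1-yl in place of ((pyridin-3-yl)methyl)amino on an aromatic carbon. For the measured compounds named here, no measured pair shows this exact change, so its size is not known from the data. Since compound 2, which also carries a ring amine at this position, gives 0.2 nM and compound 3, which likewise carries a ring amine there, gives 3.8 nM, a gain in potency relative to compound 1 is expected, though not necessarily of that extent. Compound 4 is estimated at 30 nM in this assay, within a range of 3 nM to 500 nM.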

Compound 4, inhibition constant: 146 nM
Estimate against measurement, compound 4: 4.9-fold (0.69 log units) below; the measured number falls inside the stated range.
By their numbers in this assay, from the lowest: compound 2; then compound 3; then compound 4.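

For the compounds shown here, compound 1 has no number, so no step from it to compound 4 can be read. The compounds shown leave open how large the change from ((pyridin-3-yl)methyl)amino to 4-methylpiperazin-1-yl is. No supporting measurement bears on this result.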